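The compounds below may be only part of what the source reports. "The series", "measured", "known", "first", "only" and "open" are said of these compounds alone.

Measured so far in an assay on CHO cells for antagonist activity at transient receptor potential cation channel subfamily V member 1 (Homo sapiens), read by FLIPR; a lower number here means a stronger inhibitor, a higher number a weaker inhibitor:

compound 1 `CC(C(=O)NCc1ccc(C(F)(F)F)cc1N1CCC(C)(C)CC1)c1ccc(NS(C)(=O)=O)c(F)c1` — 1.3 nM
compound 2 `CC(C(=O)NCc1ccc(C(F)(F)F)cc1-c1cccc(F)c1)c1ccc(NS(C)(=O)=O)c(F)c1` — 1.9 nM

Compound 2 has the higher of the two numbers in this assay, but the gap to compound 1, a 1.5-fold higher number from compound 1 to compound 2 (0.16 log units; within the scatter), is within the scatter, so the two stand level on these data.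

Compound 3 `COc1ccc(-c2cc(C(F)(F)F)ccc2CNC(=O)C(C)c2ccc(NS(C)(=O)=O)c(F)c2)cc1OC` is not yet measured. Against compound 2 it carries 3,4-dimethoxyphenyl in place of 3-fluorophenyl on an aromatic carbon.

Going by the values given here, the only step that bears on this position is the one from compound 1 to compound 2, a 1.5-fold higher number from compound 1 to compound 2 (0.16 log units; within the scatter), where an aromatic group took the place of a saturated ring with no change beyond the scatter. Among the compounds with values here, no step tests a change from one aromatic group to another at this position, and none tests methoxy groups anywhere. With that single step as guide, compound 3 is expected to stay close to compound 2, estimated as a 1.6-fold higher number from compound 2 to compound 3 (0.20 log units; within the scatter) in this assay. The estimate for compound 3 is therefore 3 nM, with a range from 1 nM to 10 nM.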

Compound 3, inhibition constant: 8.6 nM
Compound 3: the middle estimate sits 2.9-fold (0.46 log units) below what was measured, and the stated range covers the measured number.
By their numbers in this assay, from the lowest: compounds 1 and 2 (each within the scatter of the next); then compound 3.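

Going by these compounds alone, the position is not indifferent to which aromatic group it carries: in this assay, replacing 3-fluorophenyl with 3,4-dimethoxyphenyl gives a 4.5-fold higher number from compound 2 to compound 3 (0.66 log units; beyond the scatter), the first step beyond the scatter. Replacing 4,4-dimethylpiperidin-1-yl with the same group gives a 6.6-fold higher number from compound 1 to compound 3 (0.82 log units; beyond the scatter), so an aromatic ring at this carbon does not by itself keep the number level with the saturated ring, and the identity of its substituents matters. Nothing at hand accounts for the rise.

The change removes a fluorine and adds two methoxy groups at once, so the compounds shown cannot assign the step to any one of these. A phenyl ring with a single methoxy group, or an unsubstituted phenyl ring, would separate those contributions.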